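This account rests on a few compounds, and the source may have more. Where it says the series, first, only, none or still open, it means among the compounds named here.

Measured so far:
compound 1 `CCc1ccc(NC(=O)Nc2cc(C)nc3ccccc23)cc1`: 535 10^-6 cm/s
compound 2 `Cc1cc(NC(=O)Nc2cccc(C(N)=O)c2)c2ccccc2n1`: 2 10^-6 cm/s

In an ADME assay for permeability, using PAMPA, at pH 7.4 (a lower number here means that the compound crosses the layer more slowly, a higher number that the compound crosses the layer faster), compound 1 gives 535 10^-6 cm/s, the higher of the two numbers in hand. Going by the values given here, compound 2 gives 2 10^-6 cm/s in this assay; the gap between compound 1 and compound 2 lies well beyond the scatter, but the two structures differ in several places at once, so the gap cannot be tied to any single change and no step is drawn between them.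

Compound 3 `Cc1ccc(NC(=O)Nc2cc(C)nc3ccccc23)cc1` is next to be measured in this assay. Against compound 1 it differs in one place: hydrogen in place of methyl on a saturated chain carbon bound to an aromatic carbon. Read one bond further out, the chain on the aromatic ring goes from ethyl to methyl; the shared core and the urea link are untouched.

Among the compounds with values here, no measured pair shows what such a change does in this assay, so the expectation rests on the change alone: one carbon leaves, no ring, donor or acceptor is involved. The step from compound 1 to compound 3 is expected to be small, a 1.3-fold lower number from compound 1 to compound 3 (0.11 log units; within the scatter), within or at the edge of the scatter, with a slight lean downward. Compound 3 is estimated at 420 10^-6 cm/s, in a range from 200 10^-6 cm/s to 800 10^-6 cm/s.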

Compound 3, apparent permeability: 669 10^-6 cm/s
For compound 3 the middle estimate is 1.6-fold (0.20 log units) below the measured one, within the range that was stated.
By their numbers in this assay, from the lowest: compound 2; then compounds 1 and 3 (each within the scatter of the next).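

The series now holds its first step in one place in this assay: hydrogen in place of methyl on a saturated chain carbon bound to an aromatic carbon gives a 1.3-fold higher number from compound 1 to compound 3 (0.10 log units; within the scatter). Read as a chain, ethyl and methyl at this place cannot be told apart in this read-out, so removing this one carbon, with no ring, donor or acceptor involved, leaves no measurable mark on the number for compound 3 against compound 1. No measurement at hand speaks to why the two compounds sit together, and the result stands as an observation only.

One step of a single carbon, taken on one chain with the shared core and the urea link untouched, fixes only the short end of what this place accepts, and a longer chain such as propyl or butyl, or a chain ending in an amine, a hydroxyl or a carboxylic acid, remains unread here. Also open, as far as these compounds go, is whether the same change gives a step of similar size on a compound that carries a different group elsewhere on the ring.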